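A few compounds are considered here, and "the series" means these few. Any claim that something is new, unique, unknown or untested is made for them only; others in the source may bear on it.

The measured compounds and their values in a physicochemical assay for lipophilicity, read by HPLC, in phosphate buffer, measured as chromatographic lipophilicity, at pH 7.4; on this read-out lower numbers stand for lower lipophilicity and higher numbers for higher lipophilicity:
compound 1 `CCOc1ccc2nc(C(F)(F)F)cc(OCC(=O)Nc3cc(C)cc(C)c3)c2c1`, which gives 7.55;
compound 2 `COc1ccc2nc(C)cc(NC(=O)C(=O)Nc3cc(C)cc(C)c3)c2c1`, which gives 6.47;
compound 3 `COc1ccc2nc(C)cc(OCC(=O)Nc3ccccc3)c2c1`, which gives 4.28.

Compound 3 stands lowest of the three, beyond the scatter below compound 2 and further still below compound 1. Compound 4 `COc1ccc2nc(C)cc(OCC(=O)Nc3nccs3)c2c1` has not yet been measured in this assay. It differs from compound 3 in one place: 1,3-thiazol-2-yl in place of phenyl on an amide-type nitrogen. Within the data shown here, no measured pair shows this change, so its size rests on the structures alone. A step downward beyond the scatter is expected, since a 1,3-thiazol-2-yl ring with two hydrogen-bond acceptors replaces a phenyl ring with none. The expected step of a number 0.98 log units lower from compound 3 to compound 4 (beyond the scatter) is a clear drop. Compound 4 is therefore estimated at 3.3, with a range from 2.6 to 4.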

Compound 4, distribution coefficient: 3.2
Estimate against measurement, compound 4: 0.10 log units above; the range from low to high includes it.
By their numbers in this assay, from the lowest: compound 4; then compound 3; then compound 2; then compound 1.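

Among these compounds, replacing phenyl with 1,3-thiazol-2-yl on an amide-type nitrogen is the first single-place change here with a measured size: in this assay it gives a number 1.08 log units lower from compound 3 to compound 4 (beyond the scatter), a large step. This place therefore moves the read-out strongly when one aromatic ring is exchanged for another. No evidence accounts for the size of this step. Still open, from the compounds shown here alone, is whether a pyridin-2-yl or cyclohexyl group on that nitrogen would give a step of similar size, and whether the same change would carry over to the cores of compound 1 and compound 2.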